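Swapping the aryl group on the hydrazone carbon

This account rests on a few compounds, and the source may have more. Where it says the series, first, only, none or still open, it means among the compounds named here.

Compound 2 `CN(C)CCn1cnnc1-c1cc(Oc2ccc(NC(=O)N/N=C/c3ccc(O)c(F)c3)cc2F)ccn1` was tested in a functional assay on HT-29 cells (Homo sapiens) for cytotoxicity, read by MTT assay, with a stated time of 72 h (a lower number here means a stronger inhibitor, a higher number a weaker inhibitor), where compound 2 gives 3310 nM. For the measured compounds named here, only one other compound has been measured in the same way: compound 1 `COc1ccc(OC)c(/C=N/NC(=O)Nc2ccc(Oc3ccnc(-c4nncn4CCN(C)C)c3)c(F)c2)c1`, which in this assay gives 2070 nM. Compound 2 stands as the higher of these two numbers, but the gap between them, a 1.6-fold higher number from compound 1 to compound 2 (0.20 log units; within the scatter), is within the scatter, so the two cannot be told apart.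

Compound 3 `CN(C)CCn1cnnc1-c1cc(Oc2ccc(NC(=O)N/N=C/c3ccc(F)cc3Cl)cc2F)ccn1` differs from compound 2 in one place: 2-chloro-4-fluorophenyl in place of 3-fluoro-4-hydroxyphenyl on a carbon with a double bond to nitrogen. Going by the values given here, the only measured step that bears on this position is the one from compound 1 to compound 2, where a different aryl group was exchanged at the same carbon with a double bond to nitrogen, and that step stayed within the scatter. With so little to go on, the expectation for compound 3 in this assay is a step of about a 1.1-fold lower number from compound 2 to compound 3 (0.04 log units; within the scatter), that is, no change beyond the scatter. Compound 3 is therefore estimated at 3000 nM in this assay, with a likely range from 1200 nM to 7500 nM.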

Compound 3, half-maximal inhibitory concentration: 510 nM
For compound 3 the middle estimate is 5.9-fold (0.77 log units) above the measured one, and the stated range ends above it.
By their numbers in this assay, from the lowest: compound 3; then compounds 1 and 2 (each within the scatter of the next).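

The aryl group on the carbon with a double bond to nitrogen clearly matters in this assay, a point the earlier exchange at this carbon could not establish: 2-chloro-4-fluorophenyl in place of 3-fluoro-4-hydroxyphenyl gives (a 6.5-fold lower number from compound 2 to compound 3 (0.81 log units; beyond the scatter)), and 2-chloro-4-fluorophenyl in place of 2,5-dimethoxyphenyl gives (a 4.1-fold lower number from compound 1 to compound 3 (0.61 log units; beyond the scatter)). Compound 3 is thus the strongest inhibitor of the three, with both of its steps beyond the scatter, even though the two other aryl groups could not be told apart. Losing the hydroxyl alone does not fit as a simple reading, since compound 1 also has no hydroxyl on this ring yet stays within the scatter of compound 2.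

No measurement shown here explains why this group gives the lower number. The three compounds also leave open whether the chlorine or the fluorine on the ring carries the effect, which an unsubstituted phenyl, a 2-chlorophenyl or a 4-fluorophenyl group at the same carbon could help separate, and whether a bromine, a methyl or an amine would serve in place of the chlorine.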